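Trifluoromethylpyridinyl amine on the spirocyclic thiazole amide core

This account rests on a few compounds, and the source may have more. Where it says the series, first, only, none or still open, it means among the compounds named here.

Working notes on the spiro-cyclopropane pyrrolidine series. The shared core of compounds 2 and 3 carries a methyl-phenyl-thiazole amide and an aminomethyl arm; compound 2 `Cc1cc(C)nc(NC[C@@H]2CC3(CC3)CN2C(=O)c2nc(C)sc2-c2ccccc2)n1` gives 8.6 in a functional assay on HEK293 cells for antagonist activity at Orexin receptor type 2 (Homo sapiens), read by FLIPR and calcium flux (a lower number here means a less potent compound, a higher number a more potent compound, by a factor of ten per unit of this negative logarithm), and compound 3 `Cc1cccc(NC[C@@H]2CC3(CC3)CN2C(=O)c2nc(C)sc2-c2ccccc2)n1` gives 7.6. Compound 3 therefore stands as the lower of the two numbers, with the change a number 1.00 log units lower from compound 2 to compound 3 (beyond the scatter) lying beyond the scatter. Compound 1 `Cc1ccc(-n2nccn2)c(C(=O)N2CC3(CC3)C[C@H]2CNc2ccc(Cl)cn2)c1`, which carries a different amide part and a chloropyridinyl on the amine, returns only a limit in this assay, < 5; that value is a limit of < 5 in this assay, at which 1 of the 3 values shown sits, and not a number.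

The next compound, compound 4 `Cc1nc(C(=O)N2CC3(CC3)C[C@H]2CNc2ccc(C(F)(F)F)cn2)c(-c2ccccc2)s1`, keeps the core of compound 3 and changes only the aryl on the amine: 5-(trifluoromethyl)pyridin-2-yl in place of 6-methylpyridin-2-yl on an amine nitrogen. Among the compounds with values here, the one measured step on this amine, from a 4,6-dimethylpyrimidin-2-yl to a 6-methylpyridin-2-yl, shows that the aryl group here moves the read-out by a modest amount, but no measured pair covers a trifluoromethyl group on this core, and the only compound bearing a substituted pyridinyl at this position, compound 1, differs elsewhere as well. The expectation for compound 4 is therefore a step of a number 0.60 log units lower from compound 3 to compound 4 (beyond the scatter) with wide uncertainty. Compound 4 is estimated at 7, between 6 and 8.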

Compound 4, negative logarithm of the antagonist equilibrium constant: 7.7
Beside the measured number, compound 4's estimate is 0.70 log units below it; the range from low to high includes it.
By their numbers in this assay, from the lowest: compounds 3 and 4 (each within the scatter of the next); then compound 2. At a limit, below all of these: compound 1.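

On the shared core, the amine nitrogen accepts a 5-(trifluoromethyl)pyridin-2-yl and a 6-methylpyridin-2-yl alike: this assay shows a number 0.10 log units higher from compound 3 to compound 4 (within the scatter), so these two pyridinyl groups cannot be told apart here, although one has more heavy atoms and fluorine in place of a methyl group. The 4,6-dimethylpyrimidin-2-yl of compound 2 also stands clear of this second pyridinyl, with a number 0.90 log units lower from compound 2 to compound 4 (beyond the scatter), so the gap first seen with compound 3 is not confined to a single pyridinyl group. On this core the two pyridinyl compounds now sit together and compound 2 stands apart, and nothing in the data at hand accounts for that separation.

Still open, from the compounds shown here alone, is whether the gap follows the pyrimidine ring itself or the two methyl groups of compound 2, a question that a pyrimidin-2-yl without methyl groups on the same core would address. Also open, going by these compounds, is how far the pyridinyl result extends to other substituents on that ring, such as a nitrile or a methoxy group.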